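The compounds below may be only part of what the source reports. "The series", "measured", "known", "first", "only" and "open" are said of these compounds alone.

Measured compounds:
compound 1 `COc1ccc(/C=C/C2(C)C=CC(=O)O2)c(OC)c1OC`: 90000 nM
compound 2 `COc1c(O)ccc(/C=C/C2(C)C=CC(=O)O2)c1OC`: 131000 nM
compound 3 `CC1(/C=C/c2ccc(O)cc2)C=CC(=O)O1`: 138000 nM

All three were run in a functional assay on PC-3 cells (Homo sapiens) for inhibition, read by sulforhodamine B assay, with a stated time of 48 h; a higher number here means a weaker inhibitor of growth, a lower number a stronger inhibitor of growth. Compound 1 and compound 2 share a core; the difference between that core and the core of compound 3 is not broken down here. In this assay the three values lie close together, so no order among them is claimed.

Compound 4 `COc1ccc(/C=C/C2(C)C=CC(=O)O2)cc1` has not been measured in this assay. It differs from compound 3 by methyl in place of hydrogen on an oxygen on an aromatic ring. The same change is known from compound 2 to compound 1, namely (methyl in place of hydrogen on an oxygen on an aromatic ring), where it gave a 1.5-fold lower number from compound 2 to compound 1 (0.16 log units; within the scatter). Within the data shown here, since the two place descriptions match word for word, the earlier step is the only guide, and a step of similar size, a 1.3-fold lower number from compound 3 to compound 4 (0.10 log units; within the scatter), is expected for compound 4. On that basis compound 4 is estimated at 110000 nM in this assay, expected to fall between 60000 nM and 200000 nM.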

Compound 4, concentration for total growth inhibition: 145000 nM
For compound 4 the middle estimate is 1.3-fold (0.12 log units) below the measured one; the measured number falls inside the stated range.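

In this assay the change from hydroxy to methoxy gives a 1.1-fold higher number from compound 3 to compound 4 (0.02 log units; within the scatter). Set beside the earlier step, the change reads alike on both cores: the same change on two cores in this assay, a 1.5-fold lower number (0.16 log units; within the scatter) from compound 2 to compound 1 and a 1.1-fold higher number (0.02 log units; within the scatter) from compound 3 to compound 4, 1.5-fold (0.18 log units) apart, within the scatter of two such steps. Among these compounds, this shows that the change moves the number beyond the scatter on neither core, but with only two pairs, it assigns the change no direction and does not show that the result would hold on any other core.

The compounds shown leave open whether a longer chain on that oxygen would behave in the same way. They also leave open whether an amine or a carboxylic acid on the aromatic ring would produce a step beyond the scatter.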